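A few compounds are considered here, and "the series" means these few. Any claim that something is new, unique, unknown or untested is made for them only; others in the source may bear on it.

The measured compounds:
compound 1, `N=C(N)Nc1ccc(C(=O)NCC(=O)N2CCN(CC(=O)O)C(=O)[C@@H]2CNC(=O)c2ccc(NC(=N)N)cc2)cc1`, gives 140 nM in a functional assay for inhibition, with Cavia porcellus as the target; a higher number here means a weaker inhibitor, a lower number a stronger inhibitor
compound 2, `N=C(N)Nc1ccc(C(=O)NCC[C@H]2C(=O)N(CC(=O)O)CCN2C(=O)CNC(=O)c2ccc(NC(=N)N)cc2)cc1`, gives 97 nM in this assay
compound 3, `N=C(N)Nc1ccc(C(=O)NC[C@H]2C(=O)N(CC(=O)O)CCN2C(=O)CNC(=O)c2ccc(C(=N)N)cc2)cc1`, gives 85 nM in this assay

Compound 1 and compound 2 share a large part of their structure, but the difference between the two cores is not broken down here. Their values in this assay lie within the usual scatter of each other, so no order can be read from them. Compound 3 arises from compound 1 by one change: a group of 3 heavy atoms (1 carbon, 2 nitrogen; no ring) in place of a group of 4 heavy atoms (1 carbon, 3 nitrogen; no ring), on an aromatic carbon. That change produced a 1.6-fold lower number from compound 1 to compound 3 (0.22 log units; within the scatter).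

Compound 4, `N=C(N)Nc1ccc(C(=O)NCC[C@H]2C(=O)N(CC(=O)O)CCN2C(=O)CNC(=O)c2ccc(C(=N)N)cc2)cc1`, has not yet been measured in this assay. It arises from compound 2 by the same change, (a group of 3 heavy atoms (1 carbon, 2 nitrogen; no ring) in place of a group of 4 heavy atoms (1 carbon, 3 nitrogen; no ring), on an aromatic carbon), at a place described in the same words. On the assumption that this change behaves on the core of compound 2 as it did on the core of compound 1, a small step is expected, a 1.6-fold lower number from compound 2 to compound 4 (0.21 log units; within the scatter), because the earlier step of a 1.6-fold lower number from compound 1 to compound 3 (0.22 log units; within the scatter) stayed within the scatter. For compound 4 the estimated value in this assay is 60 nM, with an expected range from 30 nM to 120 nM.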

Compound 4, half-maximal inhibitory concentration: 37 nM
Estimate against measurement, compound 4: 1.6-fold (0.21 log units) above; the measured number falls inside the stated range.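

In this assay, putting the group of 3 heavy atoms in place of the group of 4 heavy atoms on the aromatic carbon gave a 2.6-fold lower number from compound 2 to compound 4 (0.42 log units; beyond the scatter). Set beside the earlier step on the core of compound 1, the change shows no difference between the two cores that can be told apart: the same change on two cores in this assay, a 1.6-fold lower number (0.22 log units; within the scatter) from compound 1 to compound 3 and a 2.6-fold lower number (0.42 log units; beyond the scatter) from compound 2 to compound 4, 1.6-fold (0.20 log units) apart, within the scatter of two such steps So the change carried from one core to the other without a detectable shift in its size, but only on the core of compound 2 does the step stand beyond the scatter, and two pairs say nothing about how the change would behave on any further core.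

The compounds shown leave open how a simple amine or an aminomethyl group would compare with these two groups on that aromatic carbon. They also leave open whether the same change would carry over to the other aromatic ring, or what an ester in place of the carboxylic acid would do.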